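A pyrimidin-5-yl swap at the edge of measurement

This account rests on a few compounds, and the source may have more. Where it says the series, first, only, none or still open, it means among the compounds named here.

Compound 1 `CC(O)c1ccc(C(=O)N[C@@H](C)Cn2ccc(-c3ccc(C#N)c(Cl)c3)n2)cc1` gives > 30000 nM (a limit)
Compound 2 `CC(=O)c1ccc(S(=O)(=O)N[C@@H](C)Cn2ccc(-c3ccc(C#N)c(Cl)c3)n2)cc1` gives "not determined" (no result reported) (no number)
Compound 3 `C[C@@H](Cn1ccc(-c2ccc(C#N)c(Cl)c2)n1)NS(=O)(=O)c1cn(C)cn1` gives "not determined" (no result reported) (no number)

In an ADME assay on L02 cells (Homo sapiens) for cytotoxicity, read by CCK-8 assay, with a stated time of 6 days (a higher number here means a weaker inhibitor, a lower number a stronger inhibitor), compound 1 gives > 30000 nM as its reading, and this is a limit of the assay and not a number. From the compounds shown here alone, compound 3 has no number of its own, so its standing stays open. The only entries around it are that limit and the empty entry of compound 2.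

The compound still to be measured is compound 4 `C[C@@H](Cn1ccc(-c2ccc(C#N)c(Cl)c2)n1)Nc1cncnc1` and it keeps the core of compound 3. The change is pyrimidin-5-yl in place of (1-methyl-1H-imidazol-4-yl)sulfonyl on an amine nitrogen.

Among the measured compounds shown here, no measured pair shows what such a swap does, so no step beyond the scatter is expected in this assay in either direction. For the measured compounds named here, this expectation leans on compound 1 and its limit (> 30000 nM), the only reading available. For compound 4 the expected value is 30000 nM (estimated range 12000 nM to 50000 nM).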

Compound 4, half-maximal inhibitory concentration: > 30000 nM
Compound 4 ended at the assay's limit; the forecaster's own chance of this, stated with the estimate: 70%; the middle value sits exactly at the limit.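

In this assay compound 4 gives > 30000 nM, a limit of the assay and not a number. Among the compounds shown here, compound 3 has no number to set against it, so no step between compound 3 and compound 4 can be read. From the compounds shown here alone, what replacing (1-methyl-1H-imidazol-4-yl)sulfonyl with pyrimidin-5-yl does to this reading stays open.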